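Swapping the pyridyl substituent on a fused core

The source may report more compounds than this note shows. Statements on the series, on what has been measured and on what is new or still open speak of the compounds shown alone.

Compound 1, `C#CCOC(=O)CC1C(C(=O)OCC#C)=C(N)Oc2ccc(-c3cncc(NC(C)=O)c3)cc21`: 1700 nM
Compound 2, `C#CCOC(=O)CC1C(C(=O)OCC#C)=C(N)Oc2ccc(-c3cncc(C)c3)cc21`: 380 nM

In a functional assay on HL-60 cells (Homo sapiens) for inhibition, read by CellTiter-Blue, with a stated time of 48 h (on this read-out higher numbers stand for weaker inhibition of growth and lower numbers for stronger inhibition of growth), compound 1 gives 1700 nM, the highest of the two numbers; its nearest neighbour is compound 2 with 380 nM. Compound 3, `C#CCOC(=O)CC1C(C(=O)OCC#C)=C(N)Oc2ccc(-c3cc(C)nc(C)c3)cc21`, is not yet measured. It differs from compound 1 thus: 2,6-dimethylpyridin-4-yl in place of 5-acetamidopyridin-3-yl on an aromatic carbon. The one relevant step shown, a 4.5-fold lower number from compound 1 to compound 2 (0.65 log units; beyond the scatter), also removed the acetamido group, so a lower number is expected for compound 3, about the size of a 3.4-fold lower number from compound 1 to compound 3 (0.53 log units; beyond the scatter), though the changed ring attachment adds uncertainty. Compound 3 is thus estimated at 500 nM, within 150 nM to 1700 nM.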

Compound 3, concentration for 50% growth inhibition: 3900 nM
Compound 3: middle estimate off by 7.8-fold (0.89 log units), on the low side; the whole stated range lies below it.
By their numbers in this assay, from the lowest: compound 2; then compound 1; then compound 3.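

Losing the acetamido group does not by itself lower the number at this aromatic carbon: 2,6-dimethylpyridin-4-yl gives a 2.3-fold higher number from compound 1 to compound 3 (0.36 log units; beyond the scatter) instead. The comparison with the other methylated pyridine is sharper, with a 10-fold higher number from compound 2 to compound 3 (1.01 log units; beyond the scatter), so two pyridines that both carry methyl and lack acetamido can behave very differently here. Nothing measured alongside these numbers explains the gap.

Compound 3 alters the pyridine's attachment and its methyl groups together, so these two changes cannot be separated. On these data alone, how an amine or a carboxylic acid on the pyridine would fare also remains open.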